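A few compounds are considered here, and "the series" means these few. Any claim that something is new, unique, unknown or untested is made for them only; others in the source may bear on it.

Measured compounds:
- compound 1 `Cc1nc(N2CCCC2)c2nnn(-c3ccc(C(C)C)cc3Br)c2n1` gives 194 nM in an in vitro assay on 293-EBNA cells for binding affinity to corticotropin-releasing factor receptor 1 (Homo sapiens); a higher number here means a weaker inhibitor, a lower number a stronger inhibitor
- compound 2 `CCN(CC)c1nc(C)nc2c1nnn2-c1ccc(C(C)C)cc1Br` gives 25.3 nM in this assay
- compound 3 `CCCCC(CCCC)Nc1nc(C)nc2c1nnn2-c1ccc(C(C)C)cc1Br` gives 4.5 nM in this assay

Compound 3 has the lowest number of the three, and so is the strongest binder shown: its nearest neighbour is compound 2, with a 5.6-fold lower number from compound 2 to compound 3 (0.75 log units; beyond the scatter), and the furthest is compound 1, with a 43-fold lower number from compound 1 to compound 3 (1.63 log units; beyond the scatter). All three share one core and differ only in the amine group attached to it.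

Compound 4 `CCC(CO)Nc1nc(C)nc2c1nnn2-c1ccc(C(C)C)cc1Br` has not yet been measured. It differs from compound 3 by 1-(hydroxymethyl)propyl in place of 1-butylpentyl on a nitrogen on an aromatic ring. Within the data shown here, the steps that bear on this are the two that change the same amine group: a 43-fold lower number from compound 1 to compound 3 (1.63 log units; beyond the scatter) and a 5.6-fold lower number from compound 2 to compound 3 (0.75 log units; beyond the scatter), both of which show the number falling as the group grows from a small one to the large 1-butylpentyl chain. Going the other way, to a group as small as that in compound 2 and now carrying a hydroxyl, the number is expected to rise again by a modest to large amount, a 13-fold higher number from compound 3 to compound 4 (1.12 log units; beyond the scatter). Compound 4 is therefore estimated at 60 nM, with a likely range from 15 nM to 250 nM.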

Compound 4, inhibition constant: 25.3 nM
For compound 4 the middle estimate is 2.4-fold (0.38 log units) above the measured one, and the stated range covers the measured number.
By their numbers in this assay, from the lowest: compound 3; then compounds 2 and 4 (each within the scatter of the next); then compound 1.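

Up to this point, the amine group had only been seen to give lower numbers as it grew, but in this assay a much shorter group that carries a hydroxyl, 1-(hydroxymethyl)propyl in place of 1-butylpentyl, gives a 5.6-fold higher number from compound 3 to compound 4 (0.75 log units; beyond the scatter). The comparison with diethylamino gives no change at the digits printed from compound 2 to compound 4 (within the scatter), and the one with pyrrolidin-1-yl gives a 7.7-fold lower number from compound 1 to compound 4 (0.88 log units; beyond the scatter), so a hydroxyl on this chain is compatible with a number matching that of compound 2, and the ring-containing group of compound 1 remains the weakest of the four. No measurement shown here explains these differences.

From the compounds shown here alone, what the hydroxyl itself contributes stays open, as that would take a comparison with the all-carbon 1-ethylpropyl group on this same nitrogen. Also open, going by these compounds, is how a methoxy group, a primary amine or a carboxylic acid would compare with the hydroxyl, or how a longer chain carrying the hydroxyl would.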